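The source may hold more compounds than are shown below. What is called first, only, known or untested is meant among the compounds shown, and "the series" means these compounds.

In a functional assay on MCF7 cells (Homo sapiens) for antiproliferative activity, read by MTT assay, with a stated time of 48 h (on this read-out lower numbers stand for stronger inhibition and higher numbers for weaker inhibition), compound 1 (`Cc1ccc(-c2nc(NN)c3cc(Cl)ccc3n2)cc1`) gives 3.76 ug/mL and compound 2 (`Cc1ccc(-c2nc3ccc(Cl)cc3c(=S)o2)cc1`) gives 5.18 ug/mL as its value, two numbers within the usual scatter of each other. On these numbers, compound 1 cannot be separated from compound 2. Compound 3 (`Cc1ccc(-c2nc(SCCO)c3cc(Cl)ccc3n2)cc1`) keeps the core of compound 1 and carries (2-hydroxyethyl)sulfanyl in place of aminoamino on an aromatic carbon next to the ring nitrogen ((2-hydroxyethyl)sulfanyl in place of aminoamino on an aromatic carbon). Going by the values given here, no measured step isolates this change in this assay and the data give no direct size for it. A small move toward a higher number is expected, not far beyond the scatter, since compound 2 without aminoamino still gives 5.18 ug/mL as its value. The expected change runs a 1.6-fold higher number from compound 1 to compound 3 (0.20 log units; within the scatter) as estimated here. Compound 3 is estimated at 6 ug/mL with 2.5 ug/mL to 15 ug/mL as the expected range.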

Compound 3, half-maximal inhibitory concentration: 3.76 ug/mL
The estimate for compound 3 lay 1.6-fold (0.20 log units) above the measured number; low and high end bracket the measured number.
By their numbers in this assay, from the lowest: compounds 1, 3 and 2 (each within the scatter of the next).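

In this assay, the first step readable at this position gives no change at the digits printed from compound 1 to compound 3 (within the scatter), with (2-hydroxyethyl)sulfanyl in place of aminoamino on an aromatic carbon next to the ring nitrogen. The earlier pair differed in more than this one place, whereas this step shows that, on the core of compound 1, aminoamino is not needed to keep the number where it stands, and that a group attached through sulfur can take its place. Nothing at hand bears on why the exchange leaves the number in place.

As far as these compounds go, one step cannot show how broadly this position accepts other groups, so a simple amine, a carboxylic acid or a longer chain on the sulfur remains open. From the compounds shown here alone, it also remains open whether the terminal hydroxyl of the entering group contributes anything, which the sulfur analogue without it, an ethylsulfanyl group, could address.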